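Swapping the saturated ring of compound 1 for a fluorinated aryl

The source may hold more compounds than are shown below. What is called first, only, known or untested is meant among the compounds shown, and "the series" means these compounds.

Compound 1 `O=C(O)c1ccccc1-c1ccc(CCc2ncc(CC3CCOCC3)[nH]2)cc1` gives the lowest number of the three measured compounds in an in vitro functional assay on cells for agonist activity at Bombesin receptor subtype-3 (Homo sapiens), read by luminescence and calcium flux (a higher number here means that more compound is needed for the effect, a lower number that less compound is needed), at 338 nM. Compound 2 `CCCCc1cnc(C(CCCC)Cc2ccc(-c3ccccc3C(=O)O)cc2)[nH]1` gives 2660 nM in this assay, and compound 3 `CCCCc1cnc(C(Cc2ccc(-c3ccccc3C(=O)O)cc2)C(C)C)[nH]1` gives 4620 nM. For the measured compounds named here, the only single-point step among them, a 1.7-fold higher number from compound 2 to compound 3 (0.24 log units; within the scatter), concerns a change on a different part of the molecule and sits within the scatter, so it carries little information about the new compound.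

Compound 4 `O=C(O)c1ccccc1-c1ccc(CCc2ncc(Cc3cccc(F)c3)[nH]2)cc1` differs from compound 1 in one place: 3-fluorophenyl in place of oxan-4-yl on a saturated chain carbon bound to an aromatic carbon. Going by the values given here, no measured pair shows this exchange, nor any replacement of a saturated ring by an aromatic one, so there is no direct precedent on which to lean. In the absence of such a step, the estimate for compound 4 rests on compound 1 alone, with a wide band to allow for either direction; the expected step is a 1.1-fold lower number from compound 1 to compound 4 (0.05 log units; within the scatter). Compound 4 is therefore expected to give about 300 nM in this assay, within a range of 80 nM to 1500 nM.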

Compound 4, half-maximal effective concentration: 159 nM
Compound 4: the middle estimate sits 1.9-fold (0.28 log units) above what was measured; low and high end bracket the measured number.
By their numbers in this assay, from the lowest: compound 4; then compound 1; then compounds 2 and 3 (each within the scatter of the next).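

In this assay, 3-fluorophenyl in place of oxan-4-yl on a saturated chain carbon bound to an aromatic carbon gives a 2.1-fold lower number from compound 1 to compound 4 (0.33 log units; beyond the scatter), a modest step. For the compounds shown here, this is the first reading of any change at this place, and it shows that the six-membered non-aromatic ring with its oxygen is not needed here: an aromatic ring of carbon only, with no hydrogen-bond acceptor, serves at least as well. Nothing measured on these compounds speaks to the reason for the step.

The compounds shown do not separate the contribution of the aromatic ring from that of the fluorine, and a plain benzyl group would be needed to do so. From the compounds shown here alone, how a basic amine such as piperidin-4-yl, or a chlorine on the aromatic ring, would fare at this place also remains open.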